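A few compounds are considered here, and "the series" means these few. Any claim that something is new, unique, unknown or untested is made for them only; others in the source may bear on it.

Of the compounds shown here, three from this series have been measured in a functional assay on MCF7 cells (Homo sapiens) for antiproliferative activity, read by MTT assay, with a stated time of 72 h; a higher number here means a weaker inhibitor, a lower number a stronger inhibitor. Compound 1 `CCOC(=O)c1oc2ccc(NS(=O)(=O)c3ccc(Cl)cc3)cc2c1C` gives 81200 nM, and compound 3 `CCOC(=O)c1oc2ccc(NS(=O)(=O)c3cccc(C(F)(F)F)c3)cc2c1C` gives 51400 nM. For compound 2 `CCOC(=O)c1oc2ccc(NS(=O)(=O)c3ccccc3Cl)cc2c1C` the result is a limit of the assay rather than a number, namely > 200000 nM. On the numbers shown, compound 2 therefore stands at the weak end: the step of an at least 2.4-fold higher number from compound 1 to compound 2 (0.39 log units; beyond the scatter) shows that moving the chlorine from one position on the phenyl ring to another made the inhibitor at least modestly weaker, and the fact that the value is a limit is recorded as the limit of > 200000 nM in this assay, at which 1 of the 3 values shown sits.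

Compound 4 `CCOC(=O)c1oc2ccc(NS(=O)(=O)c3ccccc3[N+](=O)[O-])cc2c1C` has not yet been measured. Compared with compound 2, the change is nitro in place of chloro on an aromatic carbon. Within the data shown here, none of the measured steps involves a nitro group, so the only step that bears on this change is the one from compound 1 to compound 2, which concerns the position of the substituent rather than its identity; it offers no direct guidance on the size or direction of the step to compound 4. With no basis for expecting a gain or loss beyond the scatter, compound 4 is expected to remain a weak inhibitor, near 150000 nM with a range from 50000 nM to 450000 nM. The estimated step of an at least 1.3-fold lower number from compound 2 to compound 4 (0.12 log units; that floor lies within the scatter) thus reflects an expectation of little change, with a real chance that the assay again reports only a limit.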

Compound 4, half-maximal inhibitory concentration: 157000 nM
For compound 4 the middle estimate is 1.0-fold (0.02 log units) below the measured one, within the range that was stated.
By their numbers in this assay, from the lowest: compounds 3, 1 and 4 (each within the scatter of the next, the first and the last beyond it). At a limit, above all of these: compound 2.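

Nitro in place of chloro on this aromatic carbon, ortho to a large group, returns a measured number, and the step reads an at least 1.2-fold lower number from compound 2 to compound 4 (0.10 log units; that floor lies within the scatter), so a real difference between the two groups can be neither claimed nor ruled out. For compound 2 the result is a limit of the assay and not a number: the limit of > 200000 nM in this assay, at which 1 of the 4 values shown sits. The step of a 1.9-fold higher number from compound 1 to compound 4 (0.29 log units; within the scatter) means that 2-nitrophenyl and 4-chlorophenyl cannot be told apart here, so a group at this place does not always end at the limit, although compound 2 remains the case that does.

The compounds shown leave open whether an amine or a methoxy group at this same place would also give a number, and whether 4-nitrophenyl would read like 4-chlorophenyl, a comparison that would separate the effect of the place from that of the group. All four compounds also share the same core, including its ethyl ester, so nothing here tells how a carboxylic acid in place of that ester would read.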